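A few compounds are considered here, and "the series" means these few. Any claim that something is new, unique, unknown or untested is made for them only; others in the source may bear on it.

- compound 1 `C=C1OC(=O)/C(=C/CCCC/C=C\CCCCCCCCC)[C@@H]1O` gives 2.58 ug/mL
- compound 2 `C=CCCCCCCCCC/C=C1/C(=O)OC(=C)[C@H]1O` gives 4.6 ug/mL

In a functional assay on MCF7 cells (Homo sapiens) for cytotoxicity (on this read-out lower numbers stand for an effect already at smaller amounts and higher numbers for an effect only at larger amounts of compound), compound 2 stands at 4.6 ug/mL and compound 1 at 2.58 ug/mL, two numbers within the usual scatter of each other, so neither can be ranked ahead.

Compound 3 `C=CCCCCCCCCC/C=C1\C(=O)OC(=C)[C@H]1O` has not yet been measured. It departs from compound 2 by the two compounds have the same atoms and bonds and differ only in configuration as drawn: 1 of 2 stereo elements differ; a double bond is drawn E in compound 2 and Z in compound 3 and in nothing else: a double bond is drawn E in compound 2 and Z in compound 3. For the measured compounds named here, no two measured compounds differ in one place, so the data offer no direct guide to this switch. No step beyond the scatter is therefore expected in this assay, in either direction. The estimated move, a 1.2-fold lower number from compound 2 to compound 3 (0.06 log units; within the scatter), stays within that scatter. Compound 3 is expected at 4 ug/mL, with an estimated range of 1.6 ug/mL to 10 ug/mL for its measurement.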

Compound 3, concentration for half-maximal effect: 4.58 ug/mL
Beside the measured number, compound 3's estimate is 1.1-fold (0.06 log units) below it; the range from low to high includes it.
By their numbers in this assay, from the lowest: compounds 1, 3 and 2 (each within the scatter of the next).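

In this assay, turning the double bond from E to Z gives a 1.0-fold lower number from compound 2 to compound 3 (0.00 log units; within the scatter), so on this read-out the drawn geometry at this position leaves no mark beyond the scatter. For the compounds shown here, this is the first direct reading of a single change, since compound 1 and compound 2 differ in more than one place. The reading can be tied to this one switch because nothing else separates the pair: the fact that compounds 2 and 3 differ only in the configuration as drawn

From the compounds shown here alone, the second stereo element is drawn alike in compound 2 and compound 3, so what its inversion would do remains open, as does whether the same indifference to double-bond geometry would hold with the chain of compound 1. Going by these compounds, how a carboxylic acid or an amine on the chain would fare in this assay also remains unknown.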